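The source may hold more compounds than are shown below. What is called first, only, known or untested is meant among the compounds shown, and "the series" means these compounds.

Compounds measured in an assay on CHO cells for displacement of a labelled ligand from 5-hydroxytryptamine receptor 1D (Homo sapiens); on this read-out higher numbers stand for weaker inhibition and lower numbers for stronger inhibition: compound 1 `C[C@@H](NC1CCN(CCCc2c[nH]c3ccc(-n4cnnc4)cc23)CC1)c1ccccc1`, 0.4 nM; compound 2 `CN(Cc1ccco1)C1CCN(CCCc2c[nH]c3ccc(-n4cnnc4)cc23)CC1`, 9.3 nM; compound 3 `CC(C)=CCN(C)C1CCN(CCCc2c[nH]c3ccc(-n4cnnc4)cc23)CC1`, 0.5 nM.

Compound 3 stands second highest of the three numbers, with compound 1 nearest and compound 2 furthest. Compound 4 `c1ccc(NCC2CCN(CCCc3c[nH]c4ccc(-n5cnnc5)cc34)CC2)nc1` differs from it: ((pyridin-2-yl)amino)methyl in place of methyl(3-methylbut-2-en-1-yl)amino on a saturated ring carbon. Within the data shown here, two measured steps bear on this change. The step of a 19-fold lower number from compound 2 to compound 3 (1.27 log units; beyond the scatter) shows that swapping an aromatic group for an alkenyl one on the side chain moved the number strongly, whereas a 1.3-fold higher number from compound 1 to compound 3 (0.10 log units; within the scatter) shows that a different aromatic-bearing substituent gave a number close to that of compound 3. With an aromatic ring entering again, a moderate rise toward compound 2 is expected, though compound 1 argues against a large one. Compound 4 is therefore estimated at 3 nM, range 0.6 nM to 15 nM, a step of a 6.0-fold higher number from compound 3 to compound 4 (0.78 log units; beyond the scatter).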

Compound 4, half-maximal inhibitory concentration: 1.7 nM
Estimate against measurement, compound 4: 1.8-fold (0.25 log units) above, and the stated range covers the measured number.
By their numbers in this assay, from the lowest: compounds 1 and 3 (each within the scatter of the next); then compound 4; then compound 2.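

In this assay, ((pyridin-2-yl)amino)methyl on this saturated ring carbon gives a modest rise, a 3.4-fold higher number from compound 3 to compound 4 (0.53 log units; beyond the scatter) and a 4.3-fold higher number from compound 1 to compound 4 (0.63 log units; beyond the scatter), yet remains clearly better than the group of compound 2, with a 5.5-fold lower number from compound 2 to compound 4 (0.74 log units; beyond the scatter). The three groups that carry an aromatic ring therefore give different numbers, so an aromatic ring alone does not fix the number at this position. Nothing shown accounts for these differences.

Which part of the entering group sets its number remains open. A (phenylamino)methyl or a ((pyridin-2-yl)oxy)methyl group would separate the contributions of the ring nitrogen and the linking amine.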